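Swapping 2,5-difluorophenyl for 2-phenylethenyl on the shared core

A few compounds are considered here, and "the series" means these few. Any claim that something is new, unique, unknown or untested is made for them only; others in the source may bear on it.

In a functional assay on MCF7 cells (Homo sapiens) for cytotoxicity, read by MTT assay, with a stated time of 96 h (on this read-out higher numbers stand for weaker inhibition and lower numbers for stronger inhibition), compound 1 `COc1cc(C(=O)c2cn(-c3ccccc3)cc2-c2ccc(N)cc2)cc(OC)c1OC` gives 9 nM. Compound 2 `COc1cccc(-c2cn(-c3ccccc3)cc2C(=O)c2cc(OC)c(OC)c(OC)c2)c1` gives 180 nM, and compound 3 `COc1cc(C(=O)c2cn(-c3ccccc3)cc2-c2cc(F)ccc2F)cc(OC)c1OC` gives 230 nM. Compound 3 sits at the weak end of these three numbers, level with its nearest neighbour, the step there being a 1.3-fold higher number from compound 2 to compound 3 (0.11 log units; within the scatter). Against the 4-aminophenyl member, the step is a 26-fold higher number from compound 1 to compound 3 (1.41 log units; beyond the scatter), and the 3-methoxyphenyl replacement gives a 20-fold higher number from compound 1 to compound 2 (1.30 log units; beyond the scatter).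

Compound 4 `COc1cc(C(=O)c2cn(-c3ccccc3)cc2/C=C/c2ccccc2)cc(OC)c1OC` keeps the shared core and changes one place, on an aromatic carbon of a five-membered aromatic ring with 1 nitrogen: 2-phenylethenyl in place of 2,5-difluorophenyl on an aromatic carbon. For the measured compounds named here, no measured compound carries 2-phenylethenyl, so there is no direct precedent. The two large steps both leave 4-aminophenyl, a group that neither compound 3 nor compound 4 carries, so they say little here. The closest guide is a 1.3-fold higher number from compound 2 to compound 3 (0.11 log units; within the scatter), an exchange between two groups other than 4-aminophenyl that produced no shift beyond the scatter. The same is expected here, with wide uncertainty on a new linking group.

The expected step is a 1.3-fold higher number from compound 3 to compound 4 (0.12 log units; within the scatter). Compound 4 is estimated at 300 nM, with an expected range from 70 nM to 1300 nM.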

Compound 4, half-maximal inhibitory concentration: 2200 nM
Estimate against measurement, compound 4: 7.3-fold (0.87 log units) below; the measured number lies above the stated range.
By their numbers in this assay, from the lowest: compound 1; then compounds 2 and 3 (each within the scatter of the next); then compound 4.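

In this assay, the position on the shared core is clearly sensitive to the group it carries, even without 4-aminophenyl in the comparison: 2-phenylethenyl gives a 9.6-fold higher number from compound 3 to compound 4 (0.98 log units; beyond the scatter) and a 12-fold higher number from compound 2 to compound 4 (1.09 log units; beyond the scatter) against the two other aryl replacements, whereas the exchange between those two gave only a 1.3-fold higher number from compound 2 to compound 3 (0.11 log units; within the scatter) and stayed within the scatter. The change from 2,5-difluorophenyl keeps the heavy-atom count and the single six-membered aromatic ring, loses both fluorines and adds one double bond outside aromatic rings, so equal size by atom count and the same ring type do not secure the same number here, and the span at this position now reaches a 240-fold higher number from compound 1 to compound 4 (2.39 log units; beyond the scatter) and is the widest shown. No measurement among the data shown accounts for this loss.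

On these data alone, whether the double bond itself matters remains open, as 2-phenylethyl, with a saturated two-carbon chain in its place, would separate that feature from the added length. For the compounds shown here, also open is whether an amine on the phenyl ring of 2-phenylethenyl would recover any of the loss, as 4-aminophenyl is the only amine-bearing group in this set.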